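The source may hold more compounds than are shown below. What is called first, only, known or untested is meant among the compounds shown, and "the series" means these compounds.

Measured so far:
Compound 1 `COc1ccc(C[C@@H]2[C@H](OC(=O)N[C@@H]3CCN(Cc4ccccc4)C3)[C@@H](O)CN2C(=O)Nc2ccc(-c3ccccc3)cc2)cc1`: in a functional assay on HEK293 cells (Homo sapiens) for inhibition (a lower number here means a stronger inhibitor, a higher number a weaker inhibitor), compound 1 gives 2000 nM.
Compound 2 `CCOC(=O)N1C[C@H](O)[C@@H](OC(=O)NCc2ccccc2-c2ccccc2)[C@H]1Cc1ccc(OC)cc1`: in this assay compound 2 gives 22000 nM.
Compound 3 `CCCOC(=O)N1C[C@H](O)[C@@H](OC(=O)NCc2ccccc2-c2ccccc2)[C@H]1Cc1ccc(OC)cc1`: in this assay compound 3 gives 9000 nM.

Compound 3 stands second highest of the three numbers; its nearest neighbour is compound 2, which lies higher, while compound 1 gives the lowest number of the set. Compound 4 `COc1ccc(C[C@@H]2[C@H](OC(=O)NCc3ccccc3-c3ccccc3)[C@@H](O)CN2C(=O)OCC(C)C)cc1` differs from compound 3 by methyl in place of hydrogen on a saturated chain carbon bound to two saturated chain carbons. For the measured compounds named here, only one measured step bears on this change, a 2.4-fold lower number from compound 2 to compound 3 (0.39 log units; beyond the scatter), which is a methyl entering the same chain one bond nearer the start. Carrying that step one carbon further out, one expects for compound 4 a step of similar, modest size in the same direction, a 1.5-fold lower number from compound 3 to compound 4 (0.18 log units; within the scatter). The estimate for compound 4 in this assay is therefore 6000 nM, with a range from 2500 nM to 15000 nM.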

Compound 4, half-maximal inhibitory concentration: 11000 nM
Compound 4: middle estimate off by 1.8-fold (0.26 log units), on the low side, within the range that was stated.
By their numbers in this assay, from the lowest: compound 1; then compounds 3, 4 and 2 (each within the scatter of the next, the first and the last beyond it).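

Adding the methyl that turns propoxy into isobutoxy gives a 1.2-fold higher number from compound 3 to compound 4 (0.09 log units; within the scatter) in this assay, so this branching produces no measurable change at this chain carbon. For the compounds shown here, the step seen earlier from ethyl to propyl therefore finds no counterpart here. The comparison with the shorter chain, a 2.0-fold lower number from compound 2 to compound 4 (0.30 log units; within the scatter), also stays within the scatter, so the isobutoxy and ethoxy compounds cannot be ordered. Whether a longer unbranched chain such as butoxy, or an amine on the chain, would give a clearly different number remains open, and nothing shown explains the flat branching step.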